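Fluoro in the Hydroxyphenyl Part of Compound 3

The compounds below may be only part of what the source reports. "The series", "measured", "known", "first", "only" and "open" are said of these compounds alone.

For the measured compounds named here, in an assay on isolated protein for inhibition of Amine oxidase [flavin-containing] B (Homo sapiens), read by fluorescence and Amplex Red, with stated times of 15 min and 20 min (a higher number here means a weaker inhibitor, a lower number a stronger inhibitor), compound 3 `Oc1ccccc1/C=N/c1ccc(OCc2ccccc2)cc1` gives 25100 nM, the second highest of the three numbers so far. Compound 1 `Cc1cccc(/C=N/c2ccc(OCc3ccccc3)cc2)c1O` gives 15500 nM in this assay, and compound 2 `O=[N+]([O-])c1ccc(O)c(/C=N/c2ccc(OCc3ccccc3)cc2)c1` gives 60900 nM. The step of a 1.6-fold higher number from compound 1 to compound 3 (0.21 log units; within the scatter) is within the scatter, so a methyl on the hydroxyphenyl part makes no reliable difference. Going by the values given here, the step of a 2.4-fold lower number from compound 2 to compound 3 (0.38 log units; beyond the scatter) is beyond the scatter, though only modestly, so a nitro on the same hydroxyphenyl part is the one change that has clearly moved the number, and it moved it upward.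

Compound 4 `Oc1ccc(F)cc1/C=N/c1ccc(OCc2ccccc2)cc1` has not yet been measured in this assay. Its difference from compound 3 is fluoro in place of hydrogen on an aromatic carbon. Both measured steps concern single substituents on the same hydroxyphenyl part, and both are relevant: one was within the scatter, the other modest. An entering group of one heavy atom is expected to give, at most, a step of about the size seen with the nitro, in the direction of a higher number, or none beyond the scatter. The estimate for compound 4 in this assay is therefore 30000 nM, with a range of 12000 nM to 75000 nM, corresponding to an expected step of a 1.2-fold higher number from compound 3 to compound 4 (0.08 log units; within the scatter).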

Compound 4, half-maximal inhibitory concentration: 15300 nM
Compound 4: middle estimate off by 2.0-fold (0.29 log units), on the high side; the range from low to high includes it.
By their numbers in this assay, from the lowest: compounds 4, 1 and 3 (each within the scatter of the next); then compound 2.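

In this assay, fluoro on the aromatic carbon para to a hydroxy group gives a 1.6-fold lower number from compound 3 to compound 4 (0.21 log units; within the scatter) and, set against the 2-hydroxy-3-methylphenyl form, a 1.0-fold lower number from compound 1 to compound 4 (0.01 log units; within the scatter), so neither comparison separates the 5-fluoro-2-hydroxyphenyl form from its neighbours. On this same carbon, the listed exchange of nitro for fluoro gives a 4.0-fold lower number from compound 2 to compound 4 (0.60 log units; beyond the scatter), which shows that the weaker inhibition of compound 2 does not extend to every group placed there: with fluoro, the number stays in the range of the unsubstituted parent. No available measurement bears on why these groups differ at this carbon.

Still open, from the compounds shown here alone, is whether a chloro, a methoxy or an amine on this carbon would stay with the fluoro or move towards the nitro, which would show how far the nitro result reaches beyond that single group. The compounds shown also leave open what a methoxy in place of the hydroxy group itself, or a carboxylic acid on the benzyloxy part, would do to the number.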